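The source may hold more compounds than are shown below. What is called first, only, known or untested is meant among the compounds shown, and "the series" means these compounds.

Compound 1 `O=C1c2ccccc2S(=O)(=O)N1CCCCCCN1CCN(c2cccc(Cl)c2)CC1` gives 233 nM in an ADME assay on HEK293 cells for displacement of a labelled ligand from 5-hydroxytryptamine receptor 7 (Homo sapiens), read by radioligand binding, with a stated time of 1 h; a lower number here means a stronger inhibitor, a higher number a weaker inhibitor.
Compound 2 `O=C1c2ccccc2S(=O)(=O)N1CCCCCCN1CCN(c2cccc(Cl)c2Cl)CC1` gives 119 nM in this assay.
Compound 3 `O=C1c2ccccc2S(=O)(=O)N1CCCCCCN1CCN(c2ccccc2C(F)(F)F)CC1` gives 195 nM in this assay.

Among these three, compound 3 gives the second highest number, yet all three sit close together: the step of a 1.2-fold lower number from compound 1 to compound 3 (0.08 log units; within the scatter) and the step of a 1.6-fold higher number from compound 2 to compound 3 (0.21 log units; within the scatter) both lie within the scatter, as does the step of a 2.0-fold lower number from compound 1 to compound 2 (0.29 log units; within the scatter). In short, swapping one aromatic group on the ring nitrogen for another has so far moved nothing beyond the noise of repeated measurement.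

Compound 4 `O=C1c2ccccc2S(=O)(=O)N1CCCCCCN1CCN(c2cccc3ccccc23)CC1` carries the same shared core and differs from compound 3 only at that position: naphthalen-1-yl in place of 2-(trifluoromethyl)phenyl on an amine nitrogen in a ring. The naphthalen-1-yl group enters at the amine nitrogen of the six-membered non-aromatic ring with two nitrogens, where the 2-(trifluoromethyl)phenyl group of compound 3 sat.

Among the measured compounds shown here, the steps that bear on this change are those that also exchanged the aromatic group on that nitrogen, namely a 1.2-fold lower number from compound 1 to compound 3 (0.08 log units; within the scatter) and a 1.6-fold higher number from compound 2 to compound 3 (0.21 log units; within the scatter), both small. The expected step from compound 3 to compound 4 is therefore a 1.3-fold lower number from compound 3 to compound 4 (0.11 log units; within the scatter), which is not expected to exceed the scatter in either direction. For compound 4 in this assay the estimated value is 150 nM, with a range from 50 nM to 500 nM.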

Compound 4, inhibition constant: 20 nM
Compound 4: the middle estimate sits 7.5-fold (0.88 log units) above what was measured; measured number below the stated range.
By their numbers in this assay, from the lowest: compound 4; then compounds 2, 3 and 1 (each within the scatter of the next).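

In this assay, this position no longer looks silent: naphthalen-1-yl on the amine nitrogen gives a 9.8-fold lower number from compound 3 to compound 4 (0.99 log units; beyond the scatter), a 6.0-fold lower number from compound 2 to compound 4 (0.77 log units; beyond the scatter) and a 12-fold lower number from compound 1 to compound 4 (1.07 log units; beyond the scatter), all beyond the scatter, whereas exchanges among the three substituted phenyl groups stayed within it. The change from compound 3 to compound 4 keeps the heavy-atom count the same and adds no hydrogen-bond donors or acceptors, but it replaces a single six-membered aromatic ring of carbon and its trifluoromethyl group with two such rings, so heavy-atom count alone does not separate the two groups. Nothing available here explains why the number falls so far with naphthalen-1-yl.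

The compounds shown leave open whether this stronger binding belongs to naphthalen-1-yl alone or would extend to other groups on the same nitrogen, such as naphthalen-2-yl or a quinoline, which has a nitrogen in its ring system. They also leave open whether it would survive a shorter or longer carbon chain between the ring nitrogen and the rest of the shared core.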